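The compounds below may be only part of what the source reports. "The series", "measured", "known", "first", "only" and "open" are said of these compounds alone.

Compound 1 `CC(C)c1c(C(=O)NCc2cccc(F)c2F)nn(-c2ccc(F)cc2)c1OC[C@@H](O)C[C@@H](O)CC(=O)O` and compound 2 `Cc1ccc(CNC(=O)c2nn(-c3ccc(F)cc3)c(OC[C@@H](O)C[C@@H](O)CC(=O)O)c2C(C)C)cc1` share a core and differ only in the group carried on the saturated chain carbon bound to the amide-type nitrogen. In a functional assay on L6 cells (Rattus norvegicus) for inhibition (on this read-out higher numbers stand for weaker inhibition and lower numbers for stronger inhibition), compound 1 gives 120 nM, while compound 2 gives 2110 nM, and the step of an 18-fold higher number from compound 1 to compound 2 (1.25 log units; beyond the scatter) shows that this position is sensitive to what is placed there. Compound 3 `COc1ccccc1CNC(=O)c1nn(-c2ccc(F)cc2)c(OC[C@@H](O)C[C@@H](O)CC(=O)O)c1C(C)C` carries a 2-methoxybenzyl group at the same place, but in this assay compound 3 gives "not determined" (no result reported), so it stands without a number among the compounds shown. Compound 4 `CC(C)c1c(C(=O)N(C)Cc2ccc(F)c(F)c2)nn(-c2ccc(F)cc2)c1OC[C@@H](O)C[C@@H](O)CC(=O)O` has not been measured. It differs from compound 3 by (3,4-difluorobenzyl)(methyl)amino in place of (2-methoxybenzyl)amino on a carbonyl carbon. Within the data shown here, no measured step covers this exact change; the step from compound 1 to compound 2 is the only one bearing on the region, and it was large. Among the measured compounds shown here, compound 4 shares its fluorinated benzyl pattern with compound 1, but the methyl on the amide-type nitrogen has no counterpart among the measured compounds, so the expectation is broad. For compound 4 in this assay a value of 600 nM is estimated, within the range 100 nM to 4000 nM.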

Compound 4, half-maximal inhibitory concentration: 4570 nM
Compound 4: the middle estimate sits 7.6-fold (0.88 log units) below what was measured; measured number above the stated range.
By their numbers in this assay, from the lowest: compound 1; then compound 2; then compound 4.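

Two fluorines on the benzyl ring do not by themselves keep the number low: the step of a 38-fold higher number from compound 1 to compound 4 (1.58 log units; beyond the scatter) shows that (3,4-difluorobenzyl)(methyl)amino on the carbonyl carbon gives up nearly all of what (2,3-difluorobenzyl)amino offers. Compound 4 also falls behind the weaker earlier compound, with a 2.2-fold higher number from compound 2 to compound 4 (0.34 log units; beyond the scatter), so it has the highest number of the three compounds with values in this assay. Nothing shown gives a reason for these differences.

As far as these compounds go, the step from compound 1 changes both the fluorine pattern and the methyl on the nitrogen, so the share of each stays open; (3,4-difluorobenzyl)amino or (2,3-difluorobenzyl)(methyl)amino on the same carbonyl carbon would separate them. Among these compounds, compound 3 has no number, so no step to it can be read, and the effect of its 2-methoxybenzyl group remains unknown.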